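Amide cap change on the shared core: chlorophenyl to cyclopropyl

The source may hold more compounds than are shown below. What is called first, only, known or untested is meant among the compounds shown, and "the series" means these compounds.

Two compounds of the series have numbers in an assay on blood for inhibition of Indoleamine 2,3-dioxygenase 1 (Homo sapiens); on this read-out higher numbers stand for weaker inhibition and lower numbers for stronger inhibition. Compound 1 `C[C@@H](C(=O)Nc1ccc(F)cc1)C1CCC2C(CCCN2C(=O)c2cccc(Cl)c2)C1` has been run repeatedly and gives 32 nM; 312 nM (2 entries), a spread wide enough to keep in mind whenever a single number is read (the several entries of compound 1 in this assay, 32 nM; 312 nM (2 entries)). Compound 2 `O=C(c1cccc(Cl)c1)N1CCCC2CC(C3(C(=O)Nc4ccc(F)cc4)CCC3)CCC21` gives 123 nM in this assay; a further entry for compound 2 carries no single number. Among the measured compounds shown here, the two values of compound 1 sit on either side of that of compound 2, and no step between these two compounds is set out, so only the bare numbers can be placed side by side.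

Compound 3 `O=C(C1CC1)N1CCCC2CC(C3(C(=O)Nc4ccc(F)cc4)CCC3)CCC21` has not yet been measured in this assay. It differs from compound 2 in one place: cyclopropyl in place of 3-chlorophenyl on a carbonyl carbon. For the measured compounds named here, no measured pair shows what this exchange does, so any expectation rests on the single number for compound 2 and on the breadth seen for compound 1. The step of a 3.3-fold higher number from compound 2 to compound 3 (0.51 log units; beyond the scatter) is estimated to run toward weaker inhibition, of a size that might still fall within the scatter. Compound 3 is therefore expected to give about 400 nM in this assay, with a plausible range from 100 nM to 1600 nM.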

Compound 3, half-maximal inhibitory concentration: 15 nM
For compound 3 the middle estimate is 27-fold (1.43 log units) above the measured one, outside the stated range (below it).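

Among the compounds shown here, at the carbonyl carbon whose other neighbour is the amide-type nitrogen in a ring, cyclopropyl in place of 3-chlorophenyl gives an 8.2-fold lower number from compound 2 to compound 3 (0.91 log units; beyond the scatter) in this assay, the only step that can be read so far, and it runs toward stronger inhibition. In this pair, neither the aromatic ring nor the chlorine of the cap is needed for inhibition at this level, since a cyclopropyl of 3 heavy atoms replaces a 3-chlorophenyl of 7 and the number still falls. The step rests on one number for each compound, and the repeated entries of another series member show how far such a number can move: the several entries of compound 1 in this assay, 32 nM; 312 nM (2 entries)

This single pair does not separate the loss of the chlorine from the loss of the aromatic ring or from the change in size; an unsubstituted phenyl, a cyclobutyl or a methyl on the same carbonyl would bear on that. Going by these compounds, whether the exchange carries over to the side chain of compound 1 also remains open.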